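This account rests on a few compounds, and the source may have more. Where it says the series, first, only, none or still open, it means among the compounds named here.

In a functional assay on MCF7 cells (Homo sapiens) for antiproliferative activity, read by MTT assay, with stated times of 24 h and 72 h (on this read-out higher numbers stand for weaker inhibition and lower numbers for stronger inhibition), the measured compounds are:

Compound 1 `COc1cc([N+](=O)[O-])c([C@@H]2[C@H](Oc3ccccc3)C(=O)N2c2cc(OC)c(OC)c(OC)c2)cc1O`: 59000 nM
Compound 2 `COc1cc(N)c([C@@H]2[C@H](Oc3ccccc3)C(=O)N2c2cc(OC)c(OC)c(OC)c2)cc1O`: 20000 nM

Compound 2 has the lower of the two numbers. For the measured compounds named here, the one measured step, a 3.0-fold lower number from compound 1 to compound 2 (0.47 log units; beyond the scatter), is modest and was made within the group that now changes. Compound 3 `COc1ccc([C@@H]2[C@H](Oc3ccccc3)C(=O)N2c2cc(OC)c(OC)c(OC)c2)cc1N` differs from compound 2 by a group of 9 heavy atoms (7 carbon, 1 nitrogen, 1 oxygen; one six-membered aromatic ring of carbon only) in place of a group of 10 heavy atoms (7 carbon, 1 nitrogen, 2 oxygen; one six-membered aromatic ring of carbon only), on a saturated ring carbon. Here 3-amino-4-methoxyphenyl enters on a saturated ring carbon of a four-membered non-aromatic ring with 1 nitrogen. Going by the values given here, no measured step covers the exchange of this whole group, so that modest step gives only a weak guide. Compound 2, at 20000 nM, leaves ample room for a fall, and a lower number is expected in this assay, though the size is uncertain. The expected change is a 67-fold lower number from compound 2 to compound 3 (1.82 log units; beyond the scatter). For compound 3 the estimate is 300 nM, with an expected range of 20 nM to 8000 nM.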

Compound 3, half-maximal inhibitory concentration: 12200 nM
Compound 3: the middle estimate sits 41-fold (1.61 log units) below what was measured, outside the stated range (above it).
By their numbers in this assay, from the lowest: compounds 3 and 2 (each within the scatter of the next); then compound 1.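

In this assay, replacing the whole aromatic group on the saturated ring carbon gives a 1.6-fold lower number from compound 2 to compound 3 (0.21 log units; within the scatter), so this read-out does not separate 3-amino-4-methoxyphenyl from the larger group of compound 2. The same entering group, set against the nitro-bearing group, gives a 4.8-fold lower number from compound 1 to compound 3 (0.68 log units; beyond the scatter), and compound 1 therefore stands apart from both amino-bearing compounds. No measurement shown here accounts for these numbers.

The compounds shown leave open whether the amino group on this aromatic ring matters at all, since no comparison here sets it against a hydroxyl, a fluorine or a bare ring carbon. They also leave open what a carboxylic acid or a longer alkoxy chain would give at the ring atom that bears the phenoxy group.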